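The compounds below may be only part of what the source reports. "The series", "measured", "known", "first", "only" and "open" are said of these compounds alone.

Measured so far:
compound 1 `C#CCCOC(=O)c1ccc(C(CC)(CC)c2ccc(OCC(=O)C(C)(C)C)c(C)c2)n1CC` with 28800 nM
compound 2 `CCOC(=O)CN(C)C(=O)c1ccc(C(CC)(CC)c2ccc(OCC(O)C(C)(C)C)c(C)c2)n1CC` with 210 nM

In an assay on HL-60 cells for agonist activity at vitamin D3 receptor (Homo sapiens), read by microscopy, with a stated time of 96 h (a lower number here means that less compound is needed, a higher number that more compound is needed for the effect), compound 2 stands lowest of the two; compound 1 gives a far higher number, well beyond the scatter. Compound 3 `CCn1c(C(=O)OCc2ccc(F)cc2)ccc1C(CC)(CC)c1ccc(OCC(O)C(C)(C)C)c(C)c1` is yet to be measured. It differs from compound 2 in one place: (4-fluorobenzyl)oxy in place of ((ethoxycarbonyl)methyl)(methyl)amino on a carbonyl carbon. Among the measured compounds shown here, no measured pair isolates this change, so the expectation rests on compound 2 alone and is uncertain. A moderate rise is expected, with a 4.8-fold higher number from compound 2 to compound 3 (0.68 log units; beyond the scatter) estimated to fall beyond the scatter. Compound 3 is therefore expected at about 1000 nM, within a range of 150 nM to 8000 nM.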

Compound 3, half-maximal effective concentration: > 50000 nM
Compound 3: no number, only a limit; the forecaster's own chance of this, stated with the estimate: 5%; middle value at least 50-fold (1.69 log units) from the limit.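

In this assay compound 3 gives > 50000 nM, which is a limit of the assay and not a number. Exchanging ((ethoxycarbonyl)methyl)(methyl)amino for (4-fluorobenzyl)oxy on this carbonyl carbon gives an at least 230-fold higher number from compound 2 to compound 3 (2.37 log units; beyond the scatter), so the group held here can move the read-out strongly. The true size of this step remains bounded rather than known: the limit of > 50000 nM in this assay, at which 1 of the 3 values shown sits.

Among the compounds shown here, the single exchange replaces the whole group, so the rise cannot be assigned to the group leaving or the group entering. On these data alone, whether a dimethylamino group, an ethoxy group or a carboxylic acid at this carbonyl carbon keeps a measurable value remains open.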